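The source may hold more compounds than are shown below. What is called first, only, known or untested is meant among the compounds shown, and "the series" means these compounds.

Measured so far:
Compound 1, `Cc1ccc(NC(=O)NC(=O)c2ccc(OCc3cccc(Cl)c3Cl)cc2)cc1-c1nc2ccccc2[nH]1`: 48500 nM
Compound 2, `Cc1ccc(NC(=O)NC(=O)c2ccc(OCc3cccc(F)c3)cc2)cc1-c1nc2ccccc2[nH]1`: 38200 nM
Compound 3, `Cc1ccc(NC(=O)NC(=O)c2ccc(OCc3ccccc3Cl)cc2)cc1-c1nc2ccccc2[nH]1`: 9010 nM

In a functional assay on HT-29 cells (Homo sapiens) for inhibition, read by MTT assay, with a stated time of 48 h (a lower number here means a stronger inhibitor, a higher number a weaker inhibitor), compound 3 gives the lowest number of the three, and both steps toward it lie beyond the scatter. Compound 4, `Cc1ccc(NC(=O)NC(=O)c2ccc(OCc3ccc(Cl)c(Cl)c3)cc2)cc1-c1nc2ccccc2[nH]1`, differs from compound 3 by 3,4-dichlorophenyl in place of 2-chlorophenyl on a saturated chain carbon bound to an oxygen on an aromatic ring. Going by the values given here, two measured steps bear on this. The step of a 5.4-fold lower number from compound 1 to compound 3 (0.73 log units; beyond the scatter) shows that removing a chloro beside the retained chloro helped modestly, and the step of a 4.2-fold lower number from compound 2 to compound 3 (0.63 log units; beyond the scatter) shows that a 3-fluorophenyl variant was modestly weaker than the 2-chlorophenyl one. Compound 4 drops the 2-chlorophenyl and carries two chloro groups on the 3,4-dichlorophenyl, so a modest step toward a weaker number is expected, a 3.3-fold higher number from compound 3 to compound 4 (0.52 log units; beyond the scatter). Compound 4 is therefore estimated at 30000 nM, ranging from 8000 nM to 100000 nM.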

Compound 4, half-maximal inhibitory concentration: 1030 nM
Compound 4: the middle estimate sits 29-fold (1.46 log units) above what was measured, outside the stated range (below it).
By their numbers in this assay, from the lowest: compound 4; then compound 3; then compounds 2 and 1 (each within the scatter of the next).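

In this assay, going by these compounds alone, the aryl group on a saturated chain carbon bound to an oxygen on an aromatic ring can shift the number much further than the earlier compounds showed (an 8.7-fold lower number from compound 3 to compound 4 (0.94 log units; beyond the scatter)), with larger gaps from the other two (a 37-fold lower number from compound 2 to compound 4 (1.57 log units; beyond the scatter); a 47-fold lower number from compound 1 to compound 4 (1.67 log units; beyond the scatter)). Since 3,4-dichlorophenyl and 2,3-dichlorophenyl both carry two chloro groups, where the chloro groups sit matters here, not merely how many there are. No measurement available here explains this difference.

As far as these compounds go, whether an amine or a carboxylic acid on this ring, or a longer chain before it, would keep the lower number stays open.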